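This account rests on a few compounds, and the source may have more. Where it says the series, first, only, none or still open, it means among the compounds named here.

In an ADME assay on MDCK cells (Canis lupus familiaris) for cytotoxicity, read by MTT assay, with a stated time of 72 h (on this read-out lower numbers stand for stronger inhibition and higher numbers for weaker inhibition), compound 1 `COc1ccc(/C=C/c2cc(C)no2)cc1OC` gives 44700 nM, and compound 2 `Cc1cc(/C=C/c2ccc(O)cc2)on1` gives 58300 nM. These two numbers lie within the usual scatter of repeated measurements, which places compound 2 level with compound 1 on the evidence available. Going by the values given here, no pair of measured compounds differing in a single place is available, leaving these two values as the only guide.

The next compound, compound 3 `COc1cc(/C=C/c2cc(C)no2)ccc1O`, differs from compound 2 by one structural change: methoxy in place of hydrogen on an aromatic carbon. In words, methoxy takes the place of hydrogen on an aromatic carbon, ortho to a hydroxy group. Methoxy is already present in compound 1 at 44700 nM, and this value is within the scatter of compound 2 at 58300 nM. This gives no reason to expect a large move in either direction. The expected outcome of a 1.2-fold lower number from compound 2 to compound 3 (0.07 log units; within the scatter) is therefore no change beyond the scatter. In this assay, the estimate for compound 3 is 50000 nM, with an expected range from 22000 nM to 110000 nM.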

Compound 3, half-maximal inhibitory concentration: 29800 nM
Compound 3: middle estimate off by 1.7-fold (0.22 log units), on the high side, within the range that was stated.
By their numbers in this assay, from the lowest: compounds 3, 1 and 2 (each within the scatter of the next).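

In this assay, going by these compounds alone, methoxy in place of hydrogen on an aromatic carbon, ortho to a hydroxy group, gives a 2.0-fold lower number from compound 2 to compound 3 (0.29 log units; within the scatter) and is the first single-place comparison at this position; the added group leaves the number indistinguishable from that of compound 2. The second comparison concerns the oxygen on the aromatic ring, where hydrogen in place of methyl gives a 1.5-fold lower number from compound 1 to compound 3 (0.18 log units; within the scatter) and so a methoxy and a hydroxy group cannot be told apart at that place on this read-out. No measurement is available that would account for either step.

These two steps cover only small groups, so the compounds shown leave open whether a longer chain, an amine or a carboxylic acid on the same aromatic carbon would move the number beyond the scatter. As far as these compounds go, it also remains open whether replacing the hydroxy group itself, for example with a fluorine atom or an amine, would give a clear difference from compound 3 in this assay or would again stay within the scatter.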